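From Iodo to Methoxy on a Shared Core

The compounds below may be only part of what the source reports. "The series", "measured", "known", "first", "only" and "open" are said of these compounds alone.

Compound 1 `Oc1cc(C(F)(F)F)ccc1-c1nc(-c2ccccc2O)n(-c2ccc(Cl)cc2)n1`: 68%
Compound 2 `Oc1cc(C(F)(F)F)ccc1-c1nc(-c2ccccc2O)n(-c2ccc(Br)cc2)n1`: 69.4%
Compound 3 `Oc1cc(C(F)(F)F)ccc1-c1nc(-c2ccccc2O)n(-c2ccc(I)cc2)n1`: 70.1%

All three compounds were tested in a functional assay on PC-12 cells (Rattus norvegicus) for cytotoxicity, read by MTT assay, with stated times of 2 h and 24 h, tested at 1 uM; a higher number here means a stronger effect of the compound at the concentration tested, a lower number a weaker effect. Compound 3 gives the highest of the three numbers, but the step of a number 0.7 percentage points higher from compound 2 to compound 3 (within the scatter) and the step of a number 2.1 percentage points higher from compound 1 to compound 3 (within the scatter) are both within the scatter, so the three compounds read as alike in this assay. The same holds for the step of a number 1.4 percentage points higher from compound 1 to compound 2 (within the scatter).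

Compound 4 `COc1ccc(-n2nc(-c3ccc(C(F)(F)F)cc3O)nc2-c2ccccc2O)cc1` differs from compound 3 in one place: methoxy in place of iodo on an aromatic carbon. Every measured step exchanges one halogen for another on that aromatic carbon, and none of them moved the number beyond the scatter. Among the compounds with values here, no measured step exchanges a halogen for methoxy, so the closest guide is the flat run across those three steps, which suggests that this position tolerates change without a clear effect in this assay.

Compound 4 is therefore expected to give about 67%, with a range from 52% to 80%. That estimate corresponds to an expected step of a number 3.1 percentage points lower from compound 3 to compound 4 (within the scatter), which would lie within the scatter.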

Compound 4, a percentage reported as activity, at one concentration (the size of the read-out at that concentration, not a potency): 69%
For compound 4 the middle estimate is 2 percentage points below the measured one, and the stated range covers the measured number.
By their numbers in this assay, from the lowest: compounds 1, 4, 2 and 3 (each within the scatter of the next).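

Until now, every measured change at this position swapped one halogen for another. Methoxy is a different kind of group, with two heavy atoms and a hydrogen-bond acceptor where iodo has one heavy atom and no acceptor, yet this assay shows a number 1.1 percentage points lower from compound 3 to compound 4 (within the scatter) and a number 0.4 percentage points lower from compound 2 to compound 4 (within the scatter) and also a number 1 percentage points higher from compound 1 to compound 4 (within the scatter). The tolerance seen at this aromatic carbon, para to a large group, therefore extends in these compounds from the halogens to methoxy, although no information on the reason for this flat result is available.

As far as these compounds go, what an amine, a carboxylic acid or a longer chain would do at this position remains open. From the compounds shown here alone, the role of the two hydroxy groups and the trifluoromethyl group also remains open, as they stay the same in all four compounds.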